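Swapping a hydroxy group for hydrogen on compound 3

A few compounds are considered here, and "the series" means these few. Any claim that something is new, unique, unknown or untested is made for them only; others in the source may bear on it.

Firm numbers are scarce in an ADME assay on Vero cells (Chlorocebus sabaeus) for cytotoxicity; a higher number here means that more compound is tolerated, a lower number that less compound is tolerated. Compound 1 `Clc1ccc(COc2ncnc3[nH]cnc23)cc1Cl` has the entry "not determined" (no result reported). Compound 2 `CCCCCCCCCCSc1ncnc2c1ncn2CC(=O)OC(C)(C)C` gives > 10 ug/mL, which is a limit of the assay and not a number. Going by the values given here, this is the only reading so far, (the limit of > 10 ug/mL in this assay, at which 1 of the 3 values shown sits). Compound 3 `CCCCCCCCCCSc1ncnc2c1ncn2C1CCCC1O` has the entry "not determined" (no result reported), so it has no number of its own to start from. Compound 4 `CCCCCCCCCCSc1ncnc2c1ncn2C1CCCC1` is still unmeasured. The structural change is hydrogen in place of hydroxy on a saturated ring carbon. Among the compounds with values here, with no measured step as a guide, no shift beyond the scatter is expected in this assay. For compound 4 the expected value is 20 ug/mL, with an estimated range of 7 ug/mL to 60 ug/mL.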

Compound 4, half-maximal cytotoxic concentration: 8.04 ug/mL
Estimate against measurement, compound 4: 2.5-fold (0.40 log units) above; the measured number falls inside the stated range.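

In this assay compound 4, with cyclopentyl on the aromatic nitrogen, gives 8.04 ug/mL as the first firm number. Compound 2, with (tert-butoxycarbonyl)methyl there, has a limit of the assay and not a number: the limit of > 10 ug/mL in this assay, at which 1 of the 4 values shown sits. The change of group therefore reads only as an at least 1.2-fold lower number from compound 2 to compound 4 (0.09 log units; that floor lies within the scatter) and its true size stays hidden. The step from 2-hydroxycyclopentyl to cyclopentyl cannot be read: compound 3 has no result. As far as these compounds go, whether an amine or a carboxylic acid on that saturated ring carbon would shift the number remains open.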